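Urea to amide on a pyrazole phenylurea series

A few compounds are considered here, and "the series" means these few. Any claim that something is new, unique, unknown or untested is made for them only; others in the source may bear on it.

In a functional assay on SK-MEL-5 cells (Homo sapiens) for inhibition, read by sulforhodamine B assay, with a stated time of 48 h, tested at 100 uM (on this read-out higher numbers stand for a weaker effect at the one concentration tested and lower numbers for a stronger effect), compound 1 `O=C(Nc1cccc(-n2cc(-c3ccncc3)c(-c3cc(O)cc(Cl)c3)n2)c1)Nc1ccc(Cl)c(C(F)(F)F)c1` gives -97%, and compound 2 `COc1cc(Cl)cc(-c2nn(-c3cccc(NC(=O)Nc4ccc(Cl)c(C(F)(F)F)c4)c3)cc2-c2ccncc2)c1` gives -77%, the higher of the two numbers shown; the only measured step, a number 20 percentage points higher from compound 1 to compound 2 (beyond the scatter), concerns a different position. Compound 3 `COc1cc(Cl)cc(-c2nn(-c3cccc(NC(=O)c4cccc(C(F)(F)F)c4)c3)cc2-c2ccncc2)c1` differs from compound 2 in this way: 3-(trifluoromethyl)phenyl in place of (4-chloro-3-(trifluoromethyl)phenyl)amino on a carbonyl carbon. Within the data shown here, no measured step bears on this change, so the expectation rests on compound 2 alone, with wide uncertainty; a step of a number 22 percentage points higher from compound 2 to compound 3 (beyond the scatter) is expected in this assay. Compound 3 is estimated at -55%, in a range from -95% to 0%.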

Compound 3, a percentage reported as activity, at one concentration (the size of the read-out at that concentration, not a potency): 20%
Beside the measured number, compound 3's estimate is 75 percentage points below it, and the stated range ends below it.
By their numbers in this assay, from the lowest: compound 1; then compound 2; then compound 3.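

In this assay, the change on the carbonyl carbon gives a number 97 percentage points higher from compound 2 to compound 3 (beyond the scatter), and compound 3 at 20% is the only one of the three with a positive number. This single step removes both the chlorine and the amino nitrogen with its hydrogen-bond donor, so this position matters strongly to the read-out. Nothing available explains the step. Which of the two losses carries the step stays open. As far as these compounds go, a 4-chloro-3-(trifluoromethyl)phenyl on the carbonyl carbon would separate them, and a thiourea in place of the urea remains equally open.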